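One Chlorine Swap, Repeated on a Second Core

A few compounds are considered here, and "the series" means these few. Any claim that something is new, unique, unknown or untested is made for them only; others in the source may bear on it.

Of the compounds shown here, three have already been tested in a functional assay on SMMC-7721 cells (Homo sapiens) for inhibition, read by MTT assay, with a stated time of 72 h, tested at 1 uM; a lower number here means a weaker effect, a higher number a stronger effect of the compound at the concentration tested. Compound 1, `Cc1cccc(COc2ccc(/C=C/C(/C=C/c3ccccn3)=N/Oc3ncnc4cccc(C)c34)cc2)c1`, gives 93.4% in this assay. Compound 2, `Cc1cccc(COc2ccc(/C=C/C(/C=C/c3ccccn3)=N/Oc3ncnc4cc(Cl)ccc34)cc2)c1`, gives 78.6% in this assay. Compound 3, `Cc1cccc2ncnc(O/N=C(\C=C\c3ccccn3)/C=C/c3ccccc3OCc3ccc(Cl)cc3)c12`, gives 93.4% in this assay, matching compound 1 to the digit, and both of these numbers stand above that of compound 2.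

The change from compound 1 to compound 2 is 7-chloroquinazolin-4-yl in place of 5-methylquinazolin-4-yl on an oxygen. Measured, this change gave a number 14.8 percentage points lower from compound 1 to compound 2 (beyond the scatter), a modest loss that lies beyond the usual scatter of such tests. How the core of compound 3 differs from the core of compound 1 is not broken down here.

Compound 4, `Clc1ccc(COc2ccccc2/C=C/C(/C=C/c2ccccn2)=N/Oc2ncnc3cc(Cl)ccc23)cc1`, is not yet measured. It differs from compound 3 by 7-chloroquinazolin-4-yl in place of 5-methylquinazolin-4-yl on an oxygen, the same change at the same kind of place. Because a number 14.8 percentage points lower from compound 1 to compound 2 (beyond the scatter) was a modest loss, compound 4 is expected to show a step of similar size, a number 14.4 percentage points lower from compound 3 to compound 4 (beyond the scatter). Compound 4 is therefore estimated at 79% in this assay, with a likely range from 66% to 90%.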

Compound 4, a percentage reported as inhibition, at one concentration (the size of the read-out at that concentration, not a potency): 94%
For compound 4 the middle estimate is 15 percentage points below the measured one; measured number above the stated range.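

The swap of 5-methylquinazolin-4-yl for 7-chloroquinazolin-4-yl did not repeat its earlier loss on the second core: in this assay the new step is a number 0.6 percentage points higher from compound 3 to compound 4 (within the scatter). The two steps disagree, so in this series the change cannot be carried from one core to another as a fixed amount: the same change on two cores in this assay, a number 14.8 percentage points lower (beyond the scatter) from compound 1 to compound 2 and a number 0.6 percentage points higher (within the scatter) from compound 3 to compound 4, 15.4 percentage points apart, beyond the scatter of two such steps. For the compounds shown here, this shows that the result of the swap depends on the rest of the molecule, but with only two pairs it does not show which difference between the cores is responsible, why the outcome differs, or which outcome a further core would follow.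

Still open, from the compounds shown here alone, is how the swap behaves on other cores, and whether a quinazolin-4-yl group carrying an amine or a methoxy group instead of the methyl or chlorine would follow either step. Also open, going by these compounds, is whether the two steps would look the same at other concentrations, since each reading comes from a single concentration and is not a potency.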